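The source may hold more compounds than are shown below. What is called first, only, known or untested is meant among the compounds shown, and "the series" means these compounds.

Measured in an ADME assay on HUVEC cells (Homo sapiens) for cytotoxicity, read by MTT assay, with a stated time of 72 h; a higher number here means a weaker inhibitor, a lower number a stronger inhibitor:
Compound 1 `C=C1CC[C@H]2C(C)(C)CCC[C@]2(C)[C@H]1CCC(C)CC(=O)OC`: > 200000 nM
Compound 2 `COc1ccc(/C=C2\CC[C@H]3C(C)(C)CCC[C@]3(C)[C@H]2CCC(C)CC(=O)O)cc1`: > 200000 nM

Compound 2 gives no number on this scale, since its > 200000 nM is a limit of this assay. Compound 1 is likewise reported only as a limit, and the data show (the limit of > 200000 nM in this assay, at which 2 of the 2 values shown sit). Among the measured compounds shown here, neither compound therefore has a position that can be ranked, and no step between measured compounds is available as a guide.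

Compound 3 `Cc1ccc(/C=C2\CC[C@H]3C(C)(C)CCC[C@]3(C)[C@H]2CCC(C)CC(=O)O)cc1` has methyl in place of methoxy on an aromatic carbon, para to a large group: methyl in place of methoxy on an aromatic carbon. With nothing to suggest otherwise, no shift beyond the scatter is expected in this assay, and a further limit is the likeliest report. The estimated change is a number no higher from compound 2 to compound 3 (the limit leaves the size open). For compound 3 the expected value is 200000 nM, with an estimated range of 70000 nM to 400000 nM.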

Compound 3, half-maximal inhibitory concentration: > 200000 nM
Compound 3: a limit, no number; the forecaster's own chance of this, stated with the estimate: 70%; the middle value lies on the limit itself.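

Compound 2 and compound 3 are both reported only as limits in this assay, so no step between them can be read: the limit of > 200000 nM in this assay, at which 3 of the 3 values shown sit.

The compounds shown leave open where any of them would fall on a numerical scale in this assay, and whether methyl in place of methoxy changes the result at all.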